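A few compounds are considered here, and "the series" means these few. Any claim that something is new, unique, unknown or untested is made for them only; others in the source may bear on it.

The three measured compounds:

Compound 1, `Cc1ccc(S(=O)(=O)c2cnc3cc(F)ccc3c2N2CCC(C)CC2)cc1C`, in an assay on isolated protein for displacement of a labelled ligand from metabotropic glutamate receptor 5 (Homo sapiens), with a stated time of 60 min, tested at 1 uM (a higher number here means more inhibition at the concentration tested (going by the name of the read-out), a lower number less inhibition), gives 90%.
Compound 2, `CC1CCN(c2c(S(=O)(=O)c3cc(F)cc(F)c3)cnc3c(F)cccc23)CC1`, in this assay gives 9%.
Compound 3, `COc1ccc(S(=O)(=O)c2cnc3ccc(Cl)cc3c2N2CCC(C)CC2)cc1Cl`, in this assay gives 46%.

Compound 1 has the highest number of the three. Compound 3 is the nearest to it, and its number is lower by a gap that goes beyond the usual scatter of repeated measurements. Compound 2 is the furthest, with a number lower by a gap that goes far beyond that scatter. Both compound 2 and compound 3 differ from compound 1 in more than one part of the molecule, so no single change can be read off from their numbers.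

The compound not yet measured is compound 4, `CC1CCN(c2c(S(=O)(=O)c3cc(Cl)cc(Cl)c3)cnc3cc(F)ccc23)CC1`. It is compound 1 with one group exchanged: 3,5-dichlorophenyl in place of 3,4-dimethylphenyl on a sulfonyl sulfur. Nothing in the three measured compounds isolates this exchange on its own, so the expected size of the step rests on a loose reading of compound 2 and compound 3, whose aryl groups also carry halogens and whose numbers are lower than that of compound 1.

On that basis a drop beyond the scatter is expected from compound 1 to compound 4, a number 30 percentage points lower from compound 1 to compound 4 (beyond the scatter), though a smaller one than seen for compound 2. For compound 4 the expected result in this assay is 60%, with a range from 25% to 90%.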

Compound 4, a percentage reported as inhibition, at one concentration (the size of the read-out at that concentration, not a potency): 87%
The estimate for compound 4 lay 27 percentage points below the measured number; the measured number falls inside the stated range.
By their numbers in this assay, from the lowest: compound 2; then compound 3; then compounds 4 and 1 (each within the scatter of the next).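

In this assay, going by these compounds alone, this is the first comparison that changes only one place: 3,5-dichlorophenyl in place of 3,4-dimethylphenyl on a sulfonyl sulfur gives a number 3 percentage points lower from compound 1 to compound 4 (within the scatter). The position therefore accepts either of these two aryl groups, which are both single carbon-only aromatic rings with the same heavy-atom count, without a change that can be told from the usual scatter, and chlorine on this ring is compatible with a high number, as compound 4 gives 87%. There is no independent measurement that explains why the two groups score alike.

As far as these compounds go, compound 2 and compound 3 differ from compound 1 in more than one place, so their steps cannot be read, and the part played by the other changes in those molecules stays unknown. From the compounds shown here alone, it also remains open how this position would respond to an aryl ring carrying a carboxylic acid or an amine, and whether compound 1 and compound 4 would still look alike in a full concentration series, since a reading at one concentration is not a potency.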